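A few compounds are considered here, and "the series" means these few. Any claim that something is new, unique, unknown or untested is made for them only; others in the source may bear on it.

Three close relatives of a single scaffold have been tested in a functional assay on BT-549 cells (Homo sapiens) for cytotoxicity, read by MTT assay, with a stated time of 48 h; a lower number here means a stronger inhibitor, a higher number a weaker inhibitor. Compound 1, `CC(C)n1c(/C=C2/C(=O)Nc3ccc(Br)cc32)nc2ccccc21`, gives 13700 nM in this assay. Compound 2, `Cn1c(/C=C2/C(=O)Nc3ccc(Br)cc32)nc2ccccc21`, carries methyl in place of isopropyl on an aromatic nitrogen. In this assay compound 2 gives > 50000 nM, which is a limit of the measurement rather than a number. The change therefore produced an at least 3.6-fold higher number from compound 1 to compound 2 (0.56 log units; beyond the scatter), a step read against (the limit of > 50000 nM in this assay, at which 1 of the 3 values shown sits). Compound 3, `CC(C)n1c(/C=C2/C(=O)Nc3ccc(Cl)cc32)nc2ccccc21`, gives 35100 nM in this assay, so that a 2.6-fold higher number from compound 1 to compound 3 (0.41 log units; beyond the scatter) and compound 3 holds the higher of the two numbers that are not limits.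

The compound still to be measured is compound 4, `Cn1c(/C=C2/C(=O)Nc3ccc(Cl)cc32)nc2ccccc21`. It stands to compound 3 as compound 2 stands to compound 1: the difference is methyl in place of isopropyl on an aromatic nitrogen, the same change as before, described at the same place in the same words for both pairs. The cores of the two pairs differ by chloro in place of bromo on an aromatic carbon.

Compound 4 is expected to give about 110000 nM, somewhere between 50000 nM and 300000 nM. That expectation rests on compound 3 starting from 35100 nM and on the earlier step of an at least 3.6-fold higher number from compound 1 to compound 2 (0.56 log units; beyond the scatter). The step is thus expected to be a 3.1-fold higher number from compound 3 to compound 4 (0.50 log units; beyond the scatter), and since compound 2 already reached the limit of > 50000 nM in this assay, at which 1 of the 3 values shown sits, from a lower starting point, compound 4 is expected to reach that limit as well.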

Compound 4, half-maximal inhibitory concentration: 39100 nM
For compound 4 the middle estimate is 2.8-fold (0.45 log units) above the measured one, outside the stated range (below it).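

Putting methyl in place of isopropyl on the aromatic nitrogen does not carry over unchanged from one core to the other: on the core of compound 3 it gives a 1.1-fold higher number from compound 3 to compound 4 (0.05 log units; within the scatter), and the two pairs disagree: the same change on two cores in this assay, an at least 3.6-fold higher number (0.56 log units; beyond the scatter) from compound 1 to compound 2 and a 1.1-fold higher number (0.05 log units; within the scatter) from compound 3 to compound 4, at least 3.2-fold (0.51 log units) apart, beyond the scatter of two such steps. Chloro in place of bromo likewise depends on its partner group, since with methyl on the nitrogen it gives an at least 1.2-fold lower number from compound 2 to compound 4 (0.10 log units; that floor lies within the scatter), and this too differs from its earlier counterpart: the same change on two cores in this assay, a 2.6-fold higher number (0.41 log units; beyond the scatter) from compound 1 to compound 3 and an at least 1.2-fold lower number (0.10 log units; that floor lies within the scatter) from compound 2 to compound 4, at least 3.2-fold (0.51 log units) apart, beyond the scatter of two such steps. On these data alone, compound 2 gives > 50000 nM, which is a limit and not a number, so the true size of each step involving it stays unknown, and two pairs show neither why the effect of the change depends on the core nor how it would behave on a third core.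

The compounds shown leave open what an ethyl group, a longer chain or a chain ending in an amine would do on the same nitrogen, on either core. They also leave open whether fluoro, iodo or methoxy in place of the bromo or chloro would follow the same pattern.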